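The source may report more compounds than this note shows. Statements on the series, on what has been measured and on what is new or still open speak of the compounds shown alone.

Measured in a functional assay on DU-145 cells (Homo sapiens) for antiproliferative activity, read by MTT assay; a lower number here means a stronger inhibitor, a higher number a weaker inhibitor:
Compound 1 `Cc1nn2c(-c3nc4cc(Cl)c(F)cc4[nH]3)c(-c3ccc(F)cc3)nc2s1`: > 30000 nM
Compound 2 `Cc1nn2c(-c3nc4cc(Cl)c(F)cc4[nH]3)c(-c3ccccc3)nc2s1`: > 30000 nM

Compound 1 stands only at a limit of this assay, > 30000 nM, with no number behind it. Compound 2 likewise gives only a limit, > 30000 nM. The evidence is thin: the limit of > 30000 nM in this assay, at which 2 of the 2 values shown sit. For the measured compounds named here, the one measured step, a step that the two limits leave unreadable from compound 1 to compound 2, has no readable size and concerns a different fluoro group.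

Compound 3 `Cc1nn2c(-c3nc4cc(Cl)c(Cl)cc4[nH]3)c(-c3ccc(F)cc3)nc2s1` differs from compound 1 by chloro in place of fluoro on an aromatic carbon, ortho to a chloro group. No direction can be drawn from these data, so the expected step, a number no higher from compound 1 to compound 3 (the limit leaves the size open), is none beyond the scatter. For compound 3 the estimated value is 30000 nM, within an expected range of 10000 nM to 60000 nM, and another limit is the likeliest report.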

Compound 3, half-maximal inhibitory concentration: > 30000 nM
Compound 3: a limit, no number (the forecaster's own chance of this, stated with the estimate: 75%); the middle value sits exactly at the limit.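

For the compounds shown here, compound 3 gives only a limit, > 30000 nM, so no new step from compound 1 to compound 3 can be read. The compounds shown leave open how chloro or fluoro on the shared core bears on potency in this assay, with no number behind any of them.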